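One more side chain on a shared core

This account rests on a few compounds, and the source may have more. Where it says the series, first, only, none or still open, it means among the compounds named here.

Of the compounds shown here, three sharing one core have been measured in a functional assay on MCF7 cells (Homo sapiens) for inhibition, read by MTT assay, with a stated time of 48 h; a higher number here means a weaker inhibitor, a lower number a stronger inhibitor. Compound 1 `CCOC(=O)C1=C(N/N=C(\c2ccc([N+](=O)[O-])cc2)N2CCN(c3ccc(F)cc3)CC2)Nc2[nH]nc(C)c2C1c1ccc(N(C)C)cc1` gives no number, only a limit of the assay: > 100000 nM. Compound 2 `CCOC(=O)C1=C(N/C=N/c2nnc(S(N)(=O)=O)s2)Nc2[nH]nc(C)c2C1c1ccc(N(C)C)cc1` gives 34500 nM. Among the measured compounds shown here, compound 3 `CCOC(=O)C1=C(N/N=C(\C#N)C(N)=O)Nc2[nH]nc(C)c2C1c1ccc(N(C)C)cc1` gives 50100 nM, which lies within the scatter of the value for compound 2 and is one of only two true numbers.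

The next compound, compound 4 `CCOC(=O)C(=NNC1=C(C(=O)OCC)C(c2ccc(N(C)C)cc2)c2c(C)n[nH]c2N1)C(=O)OCC`, carries a group of 12 heavy atoms (7 carbon, 1 nitrogen, 4 oxygen; no ring) in place of a group of 7 heavy atoms (3 carbon, 3 nitrogen, 1 oxygen; no ring), on an amine nitrogen. The group that enters has no ring, like the one it replaces. One measured exchange bears on this change, a 1.5-fold higher number from compound 2 to compound 3 (0.16 log units; within the scatter), and it swapped a group with a ring for one without at an amine nitrogen. That exchange stays within the scatter, so no step beyond the scatter is expected in this assay. The expected step is a 1.1-fold lower number from compound 3 to compound 4 (0.05 log units; within the scatter). For compound 4 the estimated value is 45000 nM, with an expected range from 18000 nM to 100000 nM.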

Compound 4, half-maximal inhibitory concentration: 89800 nM
For compound 4 the middle estimate is 2.0-fold (0.30 log units) below the measured one; measured number inside the range.
By their numbers in this assay, from the lowest: compounds 2, 3 and 4 (each within the scatter of the next, the first and the last beyond it). At a limit, above all of these: compound 1.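

Among the compounds shown here, compound 4 gives the first step at this amine nitrogen that clears the scatter, and a modest one: a 2.6-fold higher number from compound 2 to compound 4 (0.42 log units; beyond the scatter). Against the other group without a ring, the larger group does not separate in this assay, with a 1.8-fold higher number from compound 3 to compound 4 (0.25 log units; within the scatter), so having no ring is common to both compounds whose values sit higher than that of compound 2. Compound 1 stands at a limit of the assay, not a number, and the numbers of this series end not far short of it: the limit of > 100000 nM in this assay, at which 1 of the 4 values shown sits.

On these data alone, what a short chain ending in an amine or a carboxylic acid would give on this nitrogen stays open. Which feature of the entering group matters also stays open, since the groups of compound 2 and compound 4 differ in ring, size and atom counts all at once.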